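Removing One Methoxy Group: An Expected Flat Step

The compounds below may be only part of what the source reports. "The series", "measured", "known", "first", "only" and "open" are said of these compounds alone.

Of the compounds shown here, three sharing one core have been measured in a functional assay on UACC-62 cells (Homo sapiens) for inhibition, read by sulforhodamine B assay, with a stated time of 48 h; on this read-out lower numbers stand for stronger inhibition of growth and higher numbers for weaker inhibition of growth. Compound 1 `COc1ccc(-c2cc(/C=C/C(=O)c3ccc(N)cc3)[nH]n2)cc1` gives 1480 nM. Compound 2 `COc1cc(-c2cc(/C=C/C(=O)c3ccc(N)cc3)[nH]n2)cc(OC)c1OC` gives 1700 nM, and compound 3 `COc1ccc(C(=O)/C=C/c2cc(-c3cc(OC)c(OC)c(OC)c3)n[nH]2)cc1` gives 1850 nM. Compound 2 sits second highest of the three numbers, yet all three lie within the scatter of one another, so none can be called stronger or weaker than the others.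

Compound 4 `COc1ccc(-c2cc(/C=C/C(=O)c3ccc(N)cc3)[nH]n2)cc1OC` differs from compound 2 by hydrogen in place of methoxy on an aromatic carbon. Among the compounds with values here, only one single-change step is available: a 1.1-fold higher number from compound 2 to compound 3 (0.04 log units; within the scatter), which swaps a group on the other end of the molecule and does not move the number. Within the data shown here, no measured step removes a methoxy group, so there is no direct guide. No step beyond the scatter is expected in this assay for compound 4, because compound 1 sits at 1480 nM and compound 2 sits close to it at 1700 nM despite the two differing in their methoxy pattern. The change a 1.1-fold lower number from compound 2 to compound 4 (0.03 log units; within the scatter) is the estimated result. Compound 4 is therefore expected to give about 1600 nM, within a range from 800 nM to 3200 nM.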

Compound 4, concentration for 50% growth inhibition: 3110 nM
Compound 4: middle estimate off by 1.9-fold (0.29 log units), on the low side; the measured number falls inside the stated range.
By their numbers in this assay, from the lowest: compounds 1, 2, 3 and 4 (each within the scatter of the next, the first and the last beyond it).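

In this assay this change can now be read in two settings, at a place ortho to a methoxy group and meta to a large group. Taking the methoxy group away gives a 1.8-fold higher number from compound 2 to compound 4 (0.26 log units; within the scatter), but the same kind of swap starting from compound 1, with methoxy entering in place of hydrogen, gives a 2.1-fold higher number from compound 1 to compound 4 (0.32 log units; beyond the scatter), a modest weakening of growth inhibition. So the effect of a methoxy group at this place depends on the rest of the ring's methoxy pattern, and nothing measured here explains why.

Going by these compounds, it remains open how a hydroxyl group, a chlorine atom or a longer ethoxy chain at this place would compare with methoxy and hydrogen. On these data alone, whether the same dependence holds with the amino group on the other end of the molecule replaced by methoxy is also open.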